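Three compounds at the solubility limit, and an amide newcomer

A few compounds are considered here, and "the series" means these few. Any claim that something is new, unique, unknown or untested is made for them only; others in the source may bear on it.

Compound 1 `Fc1cnc(Nc2cc3[nH]c(-c4cccc(C(F)(F)F)c4)nc3cn2)c(F)c1` gives >= 50000 nM in a physicochemical assay for solubility, using the shake flask method, in simulated intestinal fluid, measured as kinetic solubility, with a stated time of 20 h, at pH 6.5; on this read-out higher numbers stand for higher solubility and lower numbers for lower solubility; this is a limit of the assay, not a number.
Compound 2 `Fc1ccc(-c2nc3cnc(Nc4ccc(C(F)(F)F)cn4)cc3[nH]2)cc1F` gives >= 50000 nM in this assay, again a limit.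
Compound 3 `Fc1ccnc(Nc2cc3[nH]c(-c4ccc(F)c(F)c4)nc3cn2)c1` gives >= 50000 nM in this assay, again a limit.

Compound 1 therefore stands where every measured compound stands: at the limit of >= 50000 nM in this assay, at which 3 of the 3 values shown sit. Within the data shown here, no pair of measured compounds differs in just one place, so no measured step exists to lean on.

Compound 4 `NC(=O)c1ccc(Nc2cc3[nH]c(-c4cccc(C(F)(F)F)c4)nc3cn2)nc1` is compound 1 with 5-carbamoylpyridin-2-yl in place of 3,5-difluoropyridin-2-yl on a nitrogen on an aromatic ring. With all three measured compounds sitting at the same limit, the step from compound 1 to compound 4 is expected to be none beyond the scatter, a number no higher from compound 1 to compound 4 (the limit leaves the size open). Compound 4 is expected to reach 50000 nM in this assay, within a range from 25000 nM to 100000 nM, most likely again reported only as a limit.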

Compound 4, solubility: < 5000 nM
Compound 4: no number, only a limit; the forecaster's own chance of this, stated with the estimate: 85%; middle value at least 10-fold (1.00 log units) from the limit.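

In this assay, this position is not indifferent: 5-carbamoylpyridin-2-yl in place of 3,5-difluoropyridin-2-yl on a nitrogen on an aromatic ring gives an at least 10-fold lower number from compound 1 to compound 4 (1.00 log units; beyond the scatter). Both ends of that step are limits of the assay, not numbers. The earlier compounds all sat at one shared limit and showed no difference, while compound 4 is the first to leave it: the limit of < 5000 nM in this assay, at which 1 of the 4 values shown sits.

The carbamoyl group arrives and the fluorines leave in the same step, and the compounds shown cannot separate the two. Going by these compounds, how a pyridin-2-yl ring carrying a carboxylic acid or an amine in place of the carbamoyl group would read also stays open.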